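The source may report more compounds than this note shows. Statements on the series, on what has been measured and on what is new or still open speak of the compounds shown alone.

Of the compounds shown here, three from this set have been tested, all in a functional assay on HeLa cells (Homo sapiens) for inhibition, read by cell counting, with a stated time of 4 days; a lower number here means a stronger inhibitor, a higher number a weaker inhibitor. Compound 1, `COc1ccc(-c2nn3cc(-c4cccc(N)c4)nc3s2)cc1OC`, carries an amine on one of its outer rings, and in this assay compound 1 gives 26000 nM. Compound 2, `C=C(Br)C(=O)Nc1cccc(-c2cn3nc(-c4ccc(C)cc4)sc3n2)c1`, replaces that amine with a bromoacrylamide, and in this assay compound 2 gives 2000 nM. Compound 3, `Nc1cccc(-c2cn3nc(-c4ccc(F)cc4)sc3n2)c1`, keeps the amine; in this assay compound 3 reaches only a limit of the assay, >= 250000 nM, so no number is known for it. Among the two numbers in hand, compound 2 has the lower one, and its distance to compound 1 is beyond the usual scatter of such measurements, with the third value standing at a limit, (the limit of >= 250000 nM in this assay, at which 1 of the 3 values shown sits).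

Compound 4, `C=C(Br)C(=O)Nc1cccc(-c2cn3nc(-c4ccccc4)sc3n2)c1`, is not yet measured. It differs from compound 2 in one place: hydrogen in place of methyl on an aromatic carbon. Cut one bond further out, the change reads 4-methylphenyl to phenyl; a methyl leaves and a hydrogen enters, and no donor or acceptor is added or lost. Among the measured compounds shown here, no measured pair in this set shows the same change, so the expectation rests on the small size of the edit alone. A step in this assay of no more than about the scatter is expected, if anything toward a slightly higher number.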

Compound 4, half-maximal inhibitory concentration: 1400 nM
The estimate for compound 4 lay 2.1-fold (0.33 log units) above the measured number; the range from low to high includes it.
By their numbers in this assay, from the lowest: compounds 4 and 2 (each within the scatter of the next); then compound 1. At a limit, above all of these: compound 3.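

In this assay, taking the methyl off the 4-methylphenyl ring gives a 1.4-fold lower number from compound 2 to compound 4 (0.15 log units; within the scatter) and so leaves the read-out unchanged as far as this assay can tell. Among the compounds shown here, this is the first step in the set between two compounds that differ in one place, and it shows that on this aromatic carbon, para to a large group, the methyl is not required for the activity seen here: phenyl and 4-methylphenyl cannot be told apart by their numbers. Nothing measured here offers an explanation for this outcome.

The compounds shown leave open whether a group of a different kind on this same carbon, such as an amine, a carboxylic acid or a longer chain, would move the number beyond the scatter, as a single methyl does not. They also leave open how much the bromoacrylamide contributes, as no two compounds shown differ only at that group, so its share cannot be read from these values.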